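Compound 4: 4-methoxyphenyl in place of 3-methoxyphenyl

This account rests on a few compounds, and the source may have more. Where it says the series, first, only, none or still open, it means among the compounds named here.

Of the compounds shown here, three have been measured in a functional assay on A549 cells (Homo sapiens) for antiproliferative activity, read by MTT assay, with a stated time of 72 h; a lower number here means a stronger inhibitor, a higher number a weaker inhibitor. Compound 1 (`COc1ncc(-c2ccc3c(c2)N(c2ccc(C)cc2)C(=O)CO3)cc1NS(=O)(=O)c1ccc(F)cc1`) gives 5870 nM. Compound 2 (`COc1cccc(N2C(=O)COc3ccc(-c4cnc(Cl)c(NS(=O)(=O)c5ccc(F)cc5)c4)cc32)c1`) gives 32700 nM. Compound 3 (`COc1cccc(N2C(=O)COc3ccc(-c4cnc(OC)c(NS(=O)(=O)c5ccc(F)cc5)c4)cc32)c1`) gives 11200 nM. That number lies within the scatter of the first and beyond the scatter of the second.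

The next compound is compound 4 (`COc1ccc(N2C(=O)COc3ccc(-c4cnc(OC)c(NS(=O)(=O)c5ccc(F)cc5)c4)cc32)cc1`), which has the same atoms as compound 3, joined differently: 4-methoxyphenyl in place of 3-methoxyphenyl on an amide-type nitrogen in a ring. It carries 4-methoxyphenyl in place of 3-methoxyphenyl on an amide-type nitrogen in a ring.

For the measured compounds named here, no measured step moves the methoxy group on this ring directly. The closest evidence is the change at the same place, a 1.9-fold higher number from compound 1 to compound 3 (0.28 log units; within the scatter). Going by the values given here, the only other step, a 2.9-fold lower number from compound 2 to compound 3 (0.47 log units; beyond the scatter), is modest, but it replaces chloro with methoxy on an aromatic carbon of a different part of the molecule, so it bears little on this change.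

In this assay no step beyond the scatter is therefore expected, with a slight lean towards a lower number, as compound 1 also carries its substituted phenyl as a 4-substituted group. The expected step is a 1.3-fold lower number from compound 3 to compound 4 (0.12 log units; within the scatter). The estimate for compound 4 is 8500 nM, with an expected range of 3500 nM to 20000 nM.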

Compound 4, half-maximal inhibitory concentration: 1350 nM
Estimate against measurement, compound 4: 6.3-fold (0.80 log units) above; measured number outside the range, below it.
By their numbers in this assay, from the lowest: compound 4; then compounds 1 and 3 (each within the scatter of the next); then compound 2.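

In this assay, the two isomers are clearly separated: 4-methoxyphenyl in place of 3-methoxyphenyl on the amide-type nitrogen in a ring gives an 8.3-fold lower number from compound 3 to compound 4 (0.92 log units; beyond the scatter), so with the same atoms, where the methoxy group sits on this phenyl ring matters to the read-out. The group on the ring matters too, as a methoxy group taking over from the methyl group on this phenyl ring gives a 4.3-fold lower number from compound 1 to compound 4 (0.64 log units; beyond the scatter), whereas the earlier change at this place, a 1.9-fold higher number from compound 1 to compound 3 (0.28 log units; within the scatter), stayed within the scatter and gave no sign of either effect. No measurement available here accounts for the difference between the two isomers.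

From the compounds shown here alone, it remains open whether the lower number is particular to 4-methoxyphenyl or extends to other groups at this place, such as 4-ethoxyphenyl, 4-(dimethylamino)phenyl or 4-carboxyphenyl, and how 2-methoxyphenyl would compare with the two isomers. Also open, going by these compounds, is whether the methoxy in place of chloro step on the other ring, a 2.9-fold lower number from compound 2 to compound 3 (0.47 log units; beyond the scatter), keeps its size when 4-methoxyphenyl sits on the amide-type nitrogen.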